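Glycerol ester of compound 3: expected minimum effective dose

The source may report more compounds than this note shows. Statements on the series, on what has been measured and on what is new or still open speak of the compounds shown alone.

In a functional assay on the whole organism (Testis, strain Long-Evans) with Rattus norvegicus as the target, with a stated time of 5 days (on this read-out higher numbers stand for an effect only at larger amounts of compound and lower numbers for an effect already at smaller amounts), compound 1 `O=C(O)c1nn(Cc2ccc(I)cc2)c2ccccc12` gives 528 mg/kg, compound 2 `O=C(O)c1nn(Cc2ccc(Cl)c(Cl)c2)c2ccccc12` gives 448 mg/kg and compound 3 `O=C(O)c1nn(Cc2cc(Cl)c(Cl)cc2Cl)c2ccccc12` gives 248 mg/kg. Compound 3 has the lowest of the three numbers; its gap to compound 2 is within the scatter, and only compound 1 stands beyond it. Among the measured compounds shown here, the single measured step, a 1.8-fold lower number from compound 2 to compound 3 (0.26 log units; within the scatter), concerns a chloro on an aromatic carbon and leaves the carboxy untouched. Compound 4 `O=C(OCC(O)CO)c1nn(Cc2cc(Cl)c(Cl)cc2Cl)c2ccccc12` differs from compound 3 by 2,3-dihydroxypropyl in place of hydrogen on an oxygen next to a carbonyl group. For the measured compounds named here, no measured step bears on a change at the oxygen next to the carbonyl, so in this assay no step beyond the scatter is expected. The expected step is a 1.1-fold higher number from compound 3 to compound 4 (0.05 log units; within the scatter). For compound 4 the estimated value is 280 mg/kg, with a range from 130 mg/kg to 600 mg/kg.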

Compound 4, minimum effective dose: 300 mg/kg
Compound 4: the middle estimate sits 1.1-fold (0.03 log units) below what was measured; measured number inside the range.
By their numbers in this assay, from the lowest: compounds 3, 4, 2 and 1 (each within the scatter of the next, the first and the last beyond it).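

In this assay, among the compounds shown here, the only change at the oxygen next to a carbonyl group gives a 1.2-fold higher number from compound 3 to compound 4 (0.08 log units; within the scatter). For this pair, then, 2,3-dihydroxypropyl in place of hydrogen on that oxygen leaves the minimum effective dose within the scatter, so a free carboxy is not required for a number in this range. No measurement shown explains this result. From the compounds shown here alone, it remains open whether a methyl ester or an amide would behave alike. Going by these compounds, it also remains open whether the same change would hold on compound 1 or compound 2.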